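The source may report more compounds than this note shows. Statements on the series, on what has been measured and on what is new or still open speak of the compounds shown alone.

Measured so far in a functional assay on NCI-H460 cells (Homo sapiens) for antiproliferative activity; a lower number here means a stronger inhibitor, a higher number a weaker inhibitor:
- compound 1 `COc1ccc(S(=O)(=O)Oc2ccccc2NC(=O)c2ccccc2)cc1`: 410 nM
- compound 2 `COc1ccc(S(=O)(=O)Oc2ccccc2NC(=O)c2ccc3ncccc3c2)cc1`: > 10000 nM, which is a limit of this assay and not a number
- compound 3 `COc1ccc(S(=O)(=O)Oc2ccccc2NC(=O)c2ccccn2)cc1`: 300 nM

Compound 3 stands at the lowest of the two numbers shown in this assay, with compound 1 nearest: the step of a 1.4-fold lower number from compound 1 to compound 3 (0.14 log units; within the scatter) lies within the scatter, so the two cannot be ordered. The value of compound 2 is a limit of this assay (the limit of > 10000 nM in this assay, at which 1 of the 3 values shown sits).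

The next compound is compound 4 `COc1ccc(S(=O)(=O)Oc2ccccc2NC(=O)c2ccnc3ccccc23)cc1`. Relative to compound 3 the change is quinolin-4-yl in place of pyridin-2-yl on a carbonyl carbon.

Among the measured compounds shown here, two measured steps bear on it. Enlarging phenyl to quinolin-6-yl on the carbonyl carbon gave an at least 24-fold higher number from compound 1 to compound 2 (1.38 log units; beyond the scatter), and the reverse move to pyridin-2-yl gave an at least 33-fold lower number from compound 2 to compound 3 (1.52 log units; beyond the scatter). Both show that a quinolinyl group on the carbonyl carbon goes with a large rise in this assay, although quinolin-4-yl itself has not been measured. A large rise is therefore expected for compound 4, a 20-fold higher number from compound 3 to compound 4 (1.30 log units; beyond the scatter), with a fair chance that only a limit is reported. The estimate for compound 4 is 6000 nM, within the range 1500 nM to 20000 nM.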

Compound 4, half-maximal inhibitory concentration: > 10000 nM
Compound 4: a limit, no number (the forecaster's own chance of this, stated with the estimate: 40%); at least 1.6-fold (0.22 log units) between middle value and limit.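

In this assay compound 4 gives > 10000 nM and this is a limit of the assay and not a number. The rise on the carbonyl carbon is therefore not confined to quinolin-6-yl: with quinolin-4-yl the series shows an at least 33-fold higher number from compound 3 to compound 4 (1.52 log units; beyond the scatter) and an at least 24-fold higher number from compound 1 to compound 4 (1.38 log units; beyond the scatter) while the step between the two quinolinyl compounds cannot be read, as both are limits. Both quinolinyl compounds now stand at the same limit: the limit of > 10000 nM in this assay, at which 2 of the 4 values shown sit.

Open, on these data alone, is whether naphthalen-2-yl, with carbon only in its rings, goes with the same rise as the quinolinyl groups, and whether an amine or a methyl on the pyridin-2-yl of compound 3 keeps a value near 300 nM in this series. As far as these compounds go, how far compound 2 and compound 4 lie past the limit also stays unknown.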